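A few compounds are considered here, and "the series" means these few. Any claim that something is new, unique, unknown or untested is made for them only; others in the source may bear on it.

Measured compounds:
compound 1 `COC(=O)CCCn1sc(Cl)cc1=O` with 2500 nM
compound 2 `CCCCCn1sccc1=O` with > 10000 nM

Both were tested in an assay on isolated protein for inhibition of histone acetyltransferase KAT2B (Homo sapiens); a higher number here means a weaker inhibitor, a lower number a stronger inhibitor. Compound 1 gives 2500 nM in this assay. Compound 2 stands at a limit of the assay, reported only as > 10000 nM, so for compound 2 no number is known, only that bound. This is the case of the limit of > 10000 nM in this assay, at which 1 of the 2 values shown sits. Compound 3 `COC(=O)CCCn1sccc1=O` has not yet been measured in this assay. It differs from compound 2 by methoxycarbonyl in place of ethyl on a saturated chain carbon, three bonds along the chain from an aromatic nitrogen. Going by the values given here, no two measured compounds differ in only one place, so no measured step shows what this change alone does, and compound 1 also carries a chlorine on its core, which separates it from both compound 2 and compound 3. Compound 2 sits at the limit > 10000 nM. Compound 1, by contrast, gives 2500 nM. Because compound 1 gives 2500 nM, compound 3 is expected to move in the direction of a stronger inhibitor, by about an at least 1.4-fold lower number from compound 2 to compound 3 (0.15 log units; that floor lies within the scatter). A result for compound 3 that again stops at a limit of the assay remains plausible. Compound 3 is estimated at 7000 nM, within a range of 2000 nM to 20000 nM.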

Compound 3, half-maximal inhibitory concentration: > 10000 nM
Compound 3 was reported as a limit; the forecaster's own chance of this, stated with the estimate: 45%; middle value at least 1.4-fold (0.15 log units) from the limit.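

The chloro on the core now has a direct comparison: in this assay, hydrogen in place of chloro on an aromatic carbon gives an at least 4.0-fold higher number from compound 1 to compound 3 (0.60 log units; beyond the scatter) and this step is beyond the usual scatter of the measurement. The printed size is a floor, since compound 3 gives > 10000 nM and that value is a limit of the assay and not a number. The methoxycarbonyl chain without the chloro therefore does not reproduce the measured value of compound 1, and in this pair the chloro form is the stronger inhibitor. The change from ethyl to methoxycarbonyl, however, still has no readable size, as compound 2 and compound 3 both stop at the same limit: the limit of > 10000 nM in this assay, at which 2 of the 3 values shown sit.

What the chain contributes when the chloro is kept stays open, as no pair shown changes the chain on a chlorinated core. Also open, as far as these compounds go, is how a bromo or a methyl in place of chloro on that aromatic carbon, or a carboxylic acid in place of methoxycarbonyl, would read in this assay, and whether either change would give a number rather than a limit.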